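The source may hold more compounds than are shown below. What is called first, only, known or untested is meant among the compounds shown, and "the series" means these compounds.

Working notes on the series. Among the measured compounds shown here, compound 1 `Cn1ccc(-c2ccccc2NCC2=NCCN2)n1` is the one member with a read number. In an in vitro functional assay on cells (Fibroblast) for agonist activity at Alpha-1B adrenergic receptor (Homo sapiens) (a lower number here means that less compound is needed, a higher number that more compound is needed for the effect), compound 1 gives 50.1 nM. Compound 2 `CCn1ccc(-c2ccccc2NCC2=NCCN2)n1` differs from compound 1 by methyl in place of hydrogen on a saturated chain carbon bound to an aromatic nitrogen. In this assay compound 2 returns only a limit, < 100000 nM. Compound 3 `Cn1cc(-c2ccccc2NCC2=NCCN2)cn1` carries a different core, the two differing by 1-methyl-1H-pyrazol-4-yl in place of 1-methyl-1H-pyrazol-3-yl on an aromatic carbon. In this assay compound 3 likewise returns only a limit, < 100000 nM. Both measured steps, a step that the limit leaves unreadable from compound 1 to compound 2 and a step that the limit leaves unreadable from compound 1 to compound 3, stay unreadable because of the limit of < 100000 nM in this assay, at which 2 of the 3 values shown sit.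

Compound 4 `CCn1cc(-c2ccccc2NCC2=NCCN2)cn1` has not yet been measured. It differs from compound 3 by methyl in place of hydrogen on a saturated chain carbon bound to an aromatic nitrogen, the same change that separates compound 1 from compound 2, at a place described in the same words, so it is the same change applied to the other core. The step expected for compound 4 is a step that the limit leaves unreadable from compound 3 to compound 4, resting on the starting point of compound 3 being only a limit and on the parallel step that the limit leaves unreadable from compound 1 to compound 2 being unreadable. Compound 4 is estimated at 20000 nM, with a range from 2000 nM to 100000 nM, and a real chance that this assay again reports only a limit.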

Compound 4, half-maximal effective concentration: < 100000 nM
Compound 4: no number, only a limit; the forecaster's own chance of this, stated with the estimate: 60%; the middle value does not contradict the limit.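

In this assay compound 4 gives only a limit, < 100000 nM. No size can be read for the step between compound 3 and compound 4 because both rest on the same limit: the limit of < 100000 nM in this assay, at which 3 of the 4 values shown sit.

The compounds shown leave open how large the effect of methyl in place of hydrogen is on either core.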